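This account rests on a few compounds, and the source may have more. Where it says the series, first, only, none or still open, it means among the compounds named here.

Measured in a functional assay on HCT-116 cells (Homo sapiens) for cytotoxicity, with a stated time of 3 days; on this read-out lower numbers stand for stronger inhibition and higher numbers for weaker inhibition:
Compound 1 `C=Cc1nc2ccccc2n1C`: 9500 nM
Compound 2 `Cn1cnc2ccccc21`: > 40000 nM

For compound 2, > 40000 nM is a limit of the assay and not a number. Compound 3 `Cn1c(Br)nc2ccccc21` carries bromo in place of hydrogen on an aromatic carbon. For the measured compounds named here, one measured step bears on this carbon: an at least 4.2-fold higher number from compound 1 to compound 2 (0.62 log units; beyond the scatter), with hydrogen in place of vinyl. Read in reverse, it links a group on this carbon to a lower number in this assay, but that rests on compound 1 alone, and no bromo compound has been measured. A change in the same direction is therefore expected, though smaller than the one seen with vinyl, and a second limit reading remains quite possible. The expected step is an at least 1.6-fold lower number from compound 2 to compound 3 (0.20 log units; that floor lies within the scatter). Compound 3 is estimated at 25000 nM, with an expected range of 9000 nM to 60000 nM.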

Compound 3, half-maximal inhibitory concentration: > 40000 nM
Compound 3 was reported as a limit; the forecaster's own chance of this, stated with the estimate: 45%; middle value at least 1.6-fold (0.20 log units) from the limit.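

In this assay compound 3 gives > 40000 nM, which is a limit of the assay and not a number. On this aromatic carbon, between two ring nitrogen atoms, bromo in place of vinyl gives an at least 4.2-fold higher number from compound 1 to compound 3 (0.62 log units; beyond the scatter), so the presence of a group here does not by itself give a reading inside the assay range. The step from hydrogen to bromo cannot be read, and compound 1 remains the only compound with a reading inside that range, as the remaining values share one limit: the limit of > 40000 nM in this assay, at which 2 of the 3 values shown sit.

As far as these compounds go, it remains open whether the reading of compound 1 is specific to vinyl or would also be seen with other carbon groups on this carbon, such as ethyl, ethynyl or phenyl. An amine or a carboxylic acid at this place would test whether groups without a carbon-carbon double bond can also give a reading inside the range.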